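The source may report more compounds than this note shows. Statements on the series, on what has been measured and on what is new or still open speak of the compounds shown alone.

Working notes on the series. Compound 1 `CSc1ccc(Cc2nn(-c3ccccc3)c(=O)c3ccccc23)cc1` is the reference point. In a functional assay on aorta with Alpha-1D adrenergic receptor (Rattus norvegicus) as the target (a lower number here means that less compound is needed, a higher number that more compound is needed for the effect), compound 1 gives only a limit, > 100000 nM, and not a number. Compound 2 `Cn1nc(Cc2ccc3ccccc3c2)c2ccccc2c1=O` in this assay also gives only a limit, > 10000 nM. Compound 3 `CC(C)(C)n1nc(Cc2ccc(Cl)cc2)c2ccccc2c1=O` in this assay gives only a limit, > 100000 nM. Within the data shown here, no two measured compounds differ in a single place, so no step size is known from the measured set; what stands is the limit of > 10000 nM in this assay, at which 1 of the 3 values shown sits, and (the limit of > 100000 nM in this assay, at which 2 of the 3 values shown sit). Compound 1 sits at the higher of the two limits, as does compound 3, while compound 2 sits at the lower one.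

Compound 4 `CSc1ccc(Cc2nn(-c3ccc([N+](=O)[O-])cc3)c(=O)c3ccccc23)cc1` differs from compound 1 by nitro in place of hydrogen on an aromatic carbon; cut one bond further out, this reads phenyl to 4-nitrophenyl. With compound 1 already at a limit in this assay, the step from compound 1 to compound 4 is expected to be none beyond the scatter, a number no higher from compound 1 to compound 4 (the limit leaves the size open). Compound 4 is expected at about 100000 nM in this assay, with a range from 30000 nM to 300000 nM, and most likely again reported only as a limit.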

Compound 4, half-maximal effective concentration: > 100000 nM
Compound 4: no number, only a limit; the forecaster's own chance of this, stated with the estimate: 85%; the middle value lies on the limit itself.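

Among these compounds, compound 1 and compound 4 both give only a limit in this assay, and no step between them can be read. The compounds shown leave open whether nitro in place of hydrogen changes the read-out at all, and whether any compound in this series gives a number in this assay.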